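Branching the ester alkoxy chain of compound 2

This account rests on a few compounds, and the source may have more. Where it says the series, first, only, none or still open, it means among the compounds named here.

Compound 2 `CCCOC(=O)C(C)ON1C(=O)c2ccccc2C1=O` gives the highest of the three numbers seen in a functional assay on the whole organism for inhibition, with Lepidium sativum as the target, tested at 1 ppm (a higher number here means more inhibition of growth at the concentration tested, a lower number less inhibition of growth), where compound 2 reaches 64%. Compound 1 `CCOC(=O)C(CC)ON1C(=O)c2ccccc2C1=O` gives 0% in this assay, and compound 3 `CCOC(=O)C(C)CN1C(=O)c2ccccc2C1=O` gives 0%, both numbers lying well beyond the scatter from that of compound 2. No pair of these compounds differs in only one place, so no single step has been measured. Compound 4 `CCC(C)OC(=O)C(C)ON1C(=O)c2ccccc2C1=O` differs from compound 2 by methyl in place of hydrogen on a saturated chain carbon bound to an oxygen next to a carbonyl group and a saturated chain carbon. Without a measured step of this kind, a moderate drop is expected for a number 19 percentage points lower from compound 2 to compound 4 (beyond the scatter), though a number close to that of compound 2 cannot be excluded. Compound 4 is therefore estimated at 45%, with a range from 10% to 75%.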

Compound 4, percent growth inhibition at one concentration: 42%
Compound 4: the middle estimate sits 3 percentage points above what was measured; the range from low to high includes it.
By their numbers in this assay, from the lowest: compounds 1 and 3 (each within the scatter of the next); then compound 4; then compound 2.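

Propyl to sec-butyl is the first single change that can be read here, and a number 22 percentage points lower from compound 2 to compound 4 (beyond the scatter) in this assay is a modest loss. Methyl in place of hydrogen on this saturated chain carbon therefore lowers the growth inhibition without abolishing it, so the branched compound 4 keeps a clear part of the inhibition seen with compound 2. Nothing available accounts for the drop.

The compounds shown leave open how isobutyl or a longer pentyl chain in place of propyl would compare, and whether a free carboxylic acid in place of the ester would retain any inhibition.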